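Notes on ring-amine substitution and maximal response

This account rests on a few compounds, and the source may have more. Where it says the series, first, only, none or still open, it means among the compounds named here.

Measured so far:
compound 1 `CC(C)S(=O)(=O)c1cnc(O[C@H]2CC[C@H](OC3CCN(C(=O)OC(C)(C)C)CC3)CC2)cn1` — 109%
compound 2 `C[C@H](CF)OC(=O)N1CCC(O[C@H]2CC[C@H](Oc3cnc(S(C)(=O)=O)cn3)CC2)CC1` — 108%

In a functional assay on isolated protein for agonist activity at Glucose-dependent insulinotropic receptor (Homo sapiens), read by HTRF and cAMP accumulation (on this read-out higher numbers stand for larger maximal responses and lower numbers for smaller maximal responses), compound 1 gives 109% and compound 2 gives 108%. Compound 2 carries the lower of the two numbers, yet its gap to compound 1 is within the scatter, so no ordering is claimed. Compound 3 `CS(=O)(=O)c1cnc(O[C@H]2CC[C@H](OC3CCN(CC4(C(F)(F)F)CCC4)CC3)CC2)cn1` is not yet measured. It differs from compound 2 thus: a group of 9 heavy atoms (6 carbon, 3 fluorine; one four-membered non-aromatic ring of carbon only) in place of a group of 7 heavy atoms (4 carbon, 2 oxygen, 1 fluorine; no ring), on an amine nitrogen in a ring. Within the data shown here, no measured step of this kind exists here. Given that compound 2 gives 108%, compound 3 is expected to move only by a number 3 percentage points lower from compound 2 to compound 3 (within the scatter), not beyond the scatter. Compound 3 is estimated at 105%, between 90% and 120%.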

Compound 3, largest response reached (Emax), in percent of the reference or control that the assay uses: 96%
Estimate against measurement, compound 3: 9 percentage points above; measured number inside the range.
By their numbers in this assay, from the lowest: compound 3; then compounds 2 and 1 (each within the scatter of the next).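

On the amine nitrogen in a ring, replacing the open-chain group of compound 2 with (1-(trifluoromethyl)cyclobutyl)methyl gives, in this assay, a number 12 percentage points lower from compound 2 to compound 3 (beyond the scatter), so the maximal response at this position depends on the substituent. The change is modest, and compound 3 still gives 96% as a substantial response. No available evidence accounts for this step.

The compounds shown leave open whether the step follows the trifluoromethyl or the cyclobutyl ring. A plain cyclobutylmethyl group or a urea on the same nitrogen could separate these possibilities.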